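Replacing an alkyne arm with a benzoxazole

This account rests on a few compounds, and the source may have more. Where it says the series, first, only, none or still open, it means among the compounds named here.

Measured so far:
- compound 1, `Nc1ccc(S(=O)(=O)N2CCN(c3ncc(C(O)(C(F)(F)F)C(F)(F)F)cc3C#CC3CC3)CC2)cn1`: 67 mL.min-1.g-1
- compound 2, `COCC#Cc1cc(C(O)(C(F)(F)F)C(F)(F)F)cnc1N1CCN(S(=O)(=O)c2ccc(N)nc2)CC1`: 399 mL.min-1.g-1

In an ADME assay (liver) for metabolic stability, with Liver microsome (Rattus norvegicus) as the target, using microsomes and NADPH, with a stated time of 30 min, tested at 1 uM (a lower number here means slower removal, a higher number faster removal of the compound), compound 2 gives 399 mL.min-1.g-1, the highest of the two numbers; its nearest neighbour is compound 1, with 67 mL.min-1.g-1. For the measured compounds named here, the single measured step, a 6.0-fold higher number from compound 1 to compound 2 (0.77 log units; beyond the scatter), swaps one small group on the triple-bonded carbon for another and was beyond the scatter.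

Compound 3, `Cc1nc2cc(-c3cc(C(O)(C(F)(F)F)C(F)(F)F)cnc3N3CCN(S(=O)(=O)c4ccc(N)nc4)CC3)ccc2o1`, is yet to be measured. It differs from compound 2 in one place: 2-methyl-1,3-benzoxazol-5-yl in place of 3-methoxyprop-1-yn-1-yl on an aromatic carbon. The whole alkyne arm is thus gone, replaced by a fused two-ring group on an aromatic carbon of the shared core.

Going by the values given here, no measured step mirrors this change. Among the compounds with values here, the one step known shows that the group at this position can move the clearance a good deal, and that the methoxymethyl-bearing compound 2 sits at the high end. Removing the methoxymethyl chain altogether is expected to bring the number part of the way back toward compound 1, so compound 3 is expected to show a step of a 2.7-fold lower number from compound 2 to compound 3 (0.42 log units; beyond the scatter). The estimate for compound 3 is 150 mL.min-1.g-1, with a range from 50 mL.min-1.g-1 to 450 mL.min-1.g-1.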

Compound 3, intrinsic clearance in microsomes: 99 mL.min-1.g-1
Compound 3: middle estimate off by 1.5-fold (0.18 log units), on the high side, within the range that was stated.
By their numbers in this assay, from the lowest: compounds 1 and 3 (each within the scatter of the next); then compound 2.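

In this assay, exchanging 3-methoxyprop-1-yn-1-yl for 2-methyl-1,3-benzoxazol-5-yl gives a 4.0-fold lower number from compound 2 to compound 3 (0.61 log units; beyond the scatter) and so shows that this aromatic carbon can carry a fused two-ring group with no triple bond at all, while the number still falls well clear of the high value seen with the methoxy-bearing arm. The comparison with the other alkyne arm, 2-cyclopropylethynyl, gives a 1.5-fold higher number from compound 1 to compound 3 (0.17 log units; within the scatter) and places compound 1 and compound 3 together, so among these three compounds a triple bond at this position is not needed for the lower numbers, and two very different groups cannot be told apart in this read-out. Nothing measured here speaks to the reason for either step.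

The compounds shown leave open whether the methyl group on the benzoxazole matters, and whether a plain phenyl ring or a pyridine on the same carbon would land with compound 1 and compound 3 or nearer compound 2. They also leave open what an amine such as morpholine, or a longer alkyne chain ending in a methoxy group, would do at this position.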